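Replacing the pyrimidine with a pyrazole on the biaryl sulfonamide

The source may report more compounds than this note shows. Statements on the series, on what has been measured and on what is new or still open speak of the compounds shown alone.

Compound 2 `COc1ccc(N2C[C@@H](C)N[C@@H](C)C2)cc1NS(=O)(=O)c1ccc(-c2cncnc2)cc1` carries a pyrimidin-5-yl group on the distal aromatic ring of its sulfonamide. In a functional assay for agonist activity at growth hormone secretagogue receptor type 1 (Homo sapiens), read by FLIPR (a lower number here means that less compound is needed, a higher number that more compound is needed for the effect), compound 2 gives 316 nM, the highest number among the two measured compounds. Its nearest neighbour is compound 1 `COc1ccc(N2C[C@@H](C)N[C@@H](C)C2)cc1NS(=O)(=O)c1ccc(-c2cc(Cl)ccc2F)cc1`, which differs only in bearing a 5-chloro-2-fluorophenyl group at the same position; in this assay compound 1 gives 0.501 nM. Among the measured compounds shown here, the single measured step, a 630-fold higher number from compound 1 to compound 2 (2.80 log units; beyond the scatter), shows how strongly this position responds when the substituted phenyl is exchanged for a six-membered diaza-aromatic ring.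

Compound 3 `COc1ccc(N2C[C@@H](C)N[C@@H](C)C2)cc1NS(=O)(=O)c1ccc(-n2cccn2)cc1` takes the next step from compound 2: 1H-pyrazol-1-yl in place of pyrimidin-5-yl on an aromatic carbon. For the measured compounds named here, no measured step bears directly on a change from one heteroaromatic ring to another at this position; the only step on record concerns the loss of the substituted phenyl, so it sets the scale but not the direction here. The estimate for compound 3 is therefore held close to compound 2, with a wide range, and the expected step of a 1.3-fold higher number from compound 2 to compound 3 (0.10 log units; within the scatter) lies within the scatter. Compound 3 is expected to give 400 nM, with a range from 80 nM to 2000 nM.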

Compound 3, half-maximal effective concentration: 15.9 nM
Estimate against measurement, compound 3: 25-fold (1.40 log units) above, and the stated range ends above it.
By their numbers in this assay, from the lowest: compound 1; then compound 3; then compound 2.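

The step from the pyrimidine to the pyrazole shows that this position distinguishes between two aromatic rings with the same count of hetero atoms, hydrogen-bond acceptors and donors: in this assay the exchange gives a large change (a 20-fold lower number from compound 2 to compound 3 (1.30 log units; beyond the scatter)). The high number of compound 2 therefore does not apply to every small diaza-aromatic ring, and the earlier step from the substituted phenyl cannot be read as a uniform penalty for such rings. Even so, the 5-chloro-2-fluorophenyl group keeps a clear lead over the pyrazole (a 32-fold higher number from compound 1 to compound 3 (1.50 log units; beyond the scatter)), so the new ring closes only part of the gap between compound 1 and compound 2, and nothing on record explains why the two heteroaromatic rings differ.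

The two rings differ at once in size and in the atom that joins them to the aromatic ring, and these compounds cannot separate those two changes. A pyrazol-4-yl group, joined through carbon, would bear on that question, while an unsubstituted phenyl would show how much of the low number of compound 1 depends on its chlorine and fluorine atoms.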